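The compounds below may be only part of what the source reports. "The series", "measured", "known", "first", "only" and "open" are said of these compounds alone.

Measured so far in a functional assay on T47D cells (Homo sapiens) for cytotoxicity, with a stated time of 72 h, tested at 50 ug/mL; a lower number here means a weaker effect, a higher number a stronger effect of the compound at the concentration tested:
compound 1, `N=c1c(=O)[nH]nc2n1CCN2c1cccc(Cl)c1` — 31%
compound 2, `Cc1ccc(N2CCn3c2n[nH]c(=O)c3=N)cc1` — 0%

For the measured compounds named here, compound 2 stands lowest of the two numbers in this assay; the only other number, that of compound 1, lies above it by a gap beyond the usual scatter. Going by the values given here, no pair of measured compounds differs in a single place, so no step size is known from the series itself.

Compound 3, `N=c1c(=O)[nH]nc2n1CCN2c1ccccc1`, is the next compound for this assay. It differs from compound 2 by hydrogen in place of methyl on an aromatic carbon.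

Among the compounds with values here, with no measured step of this kind to lean on, a small upward step is expected in this assay, of a size that may not clear the scatter; the step of a number 12 percentage points higher from compound 2 to compound 3 (beyond the scatter) is the expected one. The expectation is held modest because compound 2 gives 0%. Compound 3 is estimated at 12%, with a range from 0% to 35%.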

Compound 3, a percentage reported as inhibition, at one concentration (the size of the read-out at that concentration, not a potency): 3%
Beside the measured number, compound 3's estimate is 9 percentage points above it, and the stated range covers the measured number.
By their numbers in this assay, from the lowest: compounds 2 and 3 (each within the scatter of the next); then compound 1.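

In this assay, hydrogen in place of methyl on an aromatic carbon, para to a large group, gives a number 3 percentage points higher from compound 2 to compound 3 (within the scatter), so at this position the methyl group is not told apart from hydrogen. Hydrogen in place of chloro on an aromatic carbon gives a number 28 percentage points lower from compound 1 to compound 3 (beyond the scatter), which makes the unsubstituted ring of compound 3 a reference point and shows that, of the two substituents, only the chloro of compound 1 stands clear of it, with the modest size of that step noted. Nothing at hand accounts for the difference between these two steps.

Open, going by these compounds, is what chloro would do on the aromatic carbon that carries the methyl in compound 2. Also open, on these data alone, is how fluoro, methoxy or an amine would read on the same ring.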